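This account rests on a few compounds, and the source may have more. Where it says the series, first, only, none or still open, it means among the compounds named here.

Working notes on the series. Compound 1 `COc1ccc(C2N=C(SCc3ccccc3)NC(C)=C2C(=O)Nc2ccc(F)cc2)cc1OC` gives 12.9% in a functional assay on the whole organism (artery, strain albino) with Rattus norvegicus as the target, with a stated time of 180 min, at a dose of 10 mg/kg by the oral route; a higher number here means more inhibition at the dose given (going by the name of the read-out), a lower number less inhibition. Compound 2 `COc1ccc(C2N=C(SCc3cccc(Cl)c3)NC(C)=C2C(=O)Nc2ccc(F)cc2)cc1OC` differs from compound 1 by chloro in place of hydrogen on an aromatic carbon; in this assay compound 2 gives 13.4%, and the resulting step is a number 0.5 percentage points higher from compound 1 to compound 2 (within the scatter). Compound 3 `COc1ccc(C2N=C(SCc3ccccc3)NC(C)=C2C(=O)Nc2ccc(Br)cc2)cc1` gives 10.3% in this assay; the difference between its core and the core of compound 1 is not broken down here, so the two values are simply set side by side, and they lie within the scatter of each other.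

Compound 4 `COc1ccc(C2N=C(SCc3ccccc3Cl)NC(C)=C2C(=O)Nc2ccc(Br)cc2)cc1` is not yet measured in this assay. It differs from compound 3 by chloro in place of hydrogen on an aromatic carbon. For the measured compounds named here, this is the same kind of change as the one from compound 1 to compound 2, but not the same: in compound 2 the chloro sits meta to a large group, in compound 4 ortho to a large group. Going by the values given here, because the only measured step of this kind, a number 0.5 percentage points higher from compound 1 to compound 2 (within the scatter), lies within the scatter, the step from compound 3 to compound 4 is also expected to stay small, at a number 0.7 percentage points higher from compound 3 to compound 4 (within the scatter). Compound 4 is therefore estimated at 11%, with a range from 3% to 20%.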

Compound 4, a percentage reported as inhibition, in the whole organism at one dose (the size of the read-out at that dose, not a potency): 11.3%
For compound 4 the middle estimate is 0.3 percentage points below the measured one; measured number inside the range.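

In this assay, chloro in place of hydrogen on the benzyl group gives a number 1 percentage points higher from compound 3 to compound 4 (within the scatter). Set beside the earlier case, the step carries over from one core to the other without a visible difference: the same change on two cores in this assay, a number 0.5 percentage points higher (within the scatter) from compound 1 to compound 2 and a number 1 percentage points higher (within the scatter) from compound 3 to compound 4, 0.5 percentage points apart, within the scatter of two such steps. This supports only a limited reading: on these two cores, the change leaves the inhibition at the dose given within the scatter, whether the chloro sits ortho to a large group, as in compound 4, or elsewhere on the benzyl group, as in compound 2, but with one pair per placement it neither shows that chloro raises inhibition nor separates the effect of placement from that of the core.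

The compounds shown carry only hydrogen or chloro on the benzyl group, so it remains open whether an amine or a carboxylic acid there would give a step beyond the scatter. From the compounds shown here alone, a longer chain in place of the benzyl group is equally open.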